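From compound 2 to compound 3: working notes

A few compounds are considered here, and "the series" means these few. Any claim that something is new, unique, unknown or untested is made for them only; others in the source may bear on it.

Series so far in an ADME assay on CRL8155 cells (Homo sapiens) for cytotoxicity, read by resazurin assay, with a stated time of 72 h (on this read-out lower numbers stand for an effect already at smaller amounts and higher numbers for an effect only at larger amounts of compound), both values being limits of the assay:
Compound 1 `NCCCCNC(=O)Nc1nc2ccc(C(=O)c3ccccc3)cc2[nH]1` gives > 30000 nM as a limit
Compound 2 `NCCCCCCC(=O)Nc1nc2ccc(C(=O)c3ccccc3)cc2[nH]1` gives > 30000 nM as a limit

In this assay compound 2 gives > 30000 nM, which is a limit and not a number. Both measured compounds sit at the same limit (the limit of > 30000 nM in this assay, at which 2 of the 2 values shown sit) and neither has a number to start from. Compound 3 `O=C(CCC1CCNCC1)Nc1nc2ccc(C(=O)c3ccccc3)cc2[nH]1` is the next to be read. It carries piperidin-4-yl in place of 4-aminobutyl on a saturated chain carbon, two bonds along the chain from a carbonyl carbon. Going by the values given here, the one measured step bears on this change only loosely, as it also concerns an amine-bearing chain on the shared core. No step beyond the scatter and no direction can be expected because a step that the two limits leave unreadable from compound 1 to compound 2 gives no size to carry over. The step expected is a step that the limit leaves unreadable from compound 2 to compound 3, and a report as a limit is again the likely outcome. The estimated value for compound 3 is 35000 nM, with an expected range from 15000 nM to 70000 nM in this assay for now.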

Compound 3, half-maximal effective concentration: > 30000 nM
Compound 3: no number, only a limit; the forecaster's own chance of this, stated with the estimate: 80%; the middle value is on the limit's open side.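

In this assay compound 3 gives > 30000 nM as a limit and not a number. No step can be read from compound 2 to compound 3 or from compound 1 to compound 3, because all three compounds stand at the same limit: the limit of > 30000 nM in this assay, at which 3 of the 3 values shown sit.

The compounds shown leave open whether any change in the amine-bearing chain on the shared core shifts this read-out, and by how much.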